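Isopropyl on the amine nitrogen, tested twice for cytotoxicity

The source may hold more compounds than are shown below. What is called first, only, known or untested is meant among the compounds shown, and "the series" means these compounds.

Of the compounds shown here, three from this study have been measured in an ADME assay on L6 cells (Rattus norvegicus) for cytotoxicity, read by resazurin assay, with a stated time of 70 h; a lower number here means a stronger inhibitor, a higher number a weaker inhibitor. Compound 1 `N=C(N)c1ccc2oc(-c3cccc(OCCCOc4ccccc4)c3)cc2c1` gives 10300 nM in this assay. Compound 2 `CC(C)NC(=N)c1ccc2oc(-c3cccc(OCCCOc4ccccc4)c3)cc2c1` differs from compound 1 in one place, (isopropyl in place of hydrogen on an amine nitrogen), and compound 2 gives 26500 nM in this assay. The step between the two is a 2.6-fold higher number from compound 1 to compound 2 (0.41 log units; beyond the scatter). Compound 3 `N=C(N)c1ccc2cc(-c3cccc(OCCCCCCOc4ccccc4)c3)oc2c1` has a different core from compound 1; the difference between the two cores is not broken down here. In this assay compound 3 gives 4300 nM, the lowest of the three numbers, with compound 1 nearest and compound 2 furthest.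

Compound 4 `CC(C)NC(=N)c1ccc2cc(-c3cccc(OCCCCCCOc4ccccc4)c3)oc2c1` has not yet been measured. It stands to compound 3 as compound 2 stands to compound 1: isopropyl in place of hydrogen on an amine nitrogen. The place of the change is described in the same words in both pairs, so this is the same change made on the other core. It occurs twice among the compounds shown, and only one of those two occurrences has been measured, so the expectation rests on that single earlier step. For the measured compounds named here, the step from compound 3 to compound 4 is expected to be a 2.6-fold higher number from compound 3 to compound 4 (0.41 log units; beyond the scatter), because the one measured instance of this change reads a 2.6-fold higher number from compound 1 to compound 2 (0.41 log units; beyond the scatter). Compound 4 is therefore estimated to give about 11000 nM in this assay, with a likely range from 5000 nM to 25000 nM.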

Compound 4, half-maximal inhibitory concentration: 10100 nM
Estimate against measurement, compound 4: 1.1-fold (0.04 log units) above, and the stated range covers the measured number.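

In this assay, the change from amino to isopropylamino raised the number again on the second core, with a 2.3-fold higher number from compound 3 to compound 4 (0.37 log units; beyond the scatter), and the two steps agree: the same change on two cores in this assay, a 2.6-fold higher number (0.41 log units; beyond the scatter) from compound 1 to compound 2 and a 2.3-fold higher number (0.37 log units; beyond the scatter) from compound 3 to compound 4, 1.1-fold (0.04 log units) apart, within the scatter of two such steps

Within these two pairs, then, the step carried over from one core to the other in both direction and size, and the isopropyl compound gave the higher number each time. For the compounds shown here, this rests on only two pairs, which differ in their linking chain as well as in their core, so it cannot show which of those differences, if either, matters to the step, nor that the step would hold on any further core or in any other assay; the numbers also give no reason why the isopropyl compounds read higher.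

The compounds shown leave open whether a smaller group such as methyl, or a ring such as cyclopentyl, on the same amine nitrogen would shift the number in the same way. They also leave open whether the step would persist with a longer chain or with the shorter chain on the core of compound 3.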